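Benzylsulfanyl to ethylsulfanyl on the shared core

This account rests on a few compounds, and the source may have more. Where it says the series, first, only, none or still open, it means among the compounds named here.

Compound 1 `Nc1nn2c(O)cc(-c3ccccc3)nc2c1[N+](=O)[O-]` carries a phenyl directly on the shared core. In a functional assay on K562 cells (Homo sapiens) for inhibition (on this read-out lower numbers stand for stronger inhibition of growth and higher numbers for weaker inhibition of growth), compound 1 gives only a limit, > 50 ug/mL, and no number. Compound 2 `Nc1nn2c(O)cc(CNC(N)SCc3ccccc3)nc2c1[N+](=O)[O-]` carries instead a side chain ending in a benzylsulfanyl group. In this assay compound 2 likewise gives only a limit, > 50 ug/mL, not a measured number. Both values shown in this assay sit at the limit of > 50 ug/mL in this assay, at which 2 of the 2 values shown sit, so compound 2 stands level with compound 1 and nothing separates the two on the numbers available.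

Compound 3 `CCSC(N)NCc1cc(O)n2nc(N)c([N+](=O)[O-])c2n1` has not yet been measured in this assay. It differs from compound 2 by methyl in place of phenyl on a saturated chain carbon bound to a sulfur, which, cut one bond further out, reads benzyl to ethyl, or benzylsulfanyl to ethylsulfanyl. Going by the values given here, no step between measured compounds covers this change, so no measured size can be quoted for it. Compound 3 is expected to move by a step that the limit leaves unreadable from compound 2 to compound 3, nothing beyond the scatter and in no particular direction. For compound 3 the estimate in this assay is 60 ug/mL, within 25 ug/mL to 150 ug/mL, most probably reported again as a limit rather than a number.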

Compound 3, concentration for 50% growth inhibition: > 50 ug/mL
Compound 3 ended at the assay's limit (the forecaster's own chance of this, stated with the estimate: 80%); the middle value lies beyond the limit too.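

In this assay compound 3 gives > 50 ug/mL as a limit and not a number. The steps from compound 1 and from compound 2 to compound 3 therefore cannot be read: the limit of > 50 ug/mL in this assay, at which 3 of the 3 values shown sit.

The compounds shown leave open how strongly any of the three inhibits growth, and whether benzylsulfanyl to ethylsulfanyl changes it at all.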